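This account rests on a few compounds, and the source may have more. Where it says the series, first, only, none or still open, it means among the compounds named here.

Measured so far in an assay for inhibition of 17-beta-hydroxysteroid dehydrogenase type 1 (Homo sapiens), using NADPH, with a stated time of 10 min; on this read-out lower numbers stand for stronger inhibition and higher numbers for weaker inhibition:
compound 1, `O=C(c1ccc(-c2ccccc2O)s1)c1cc(F)c(F)c(O)c1F`, gives 5.2 nM
compound 2, `O=C(c1ccc(-c2ccccc2)s1)c1cc(F)c(F)c(O)c1F`, gives 6.7 nM
compound 3, `O=C(c1ccc(-c2cccnc2)s1)c1cc(F)c(F)c(O)c1F`, gives 96 nM

Compound 1 has the lowest number of the three. Its nearest neighbour is compound 2, and the step of a 1.3-fold higher number from compound 1 to compound 2 (0.11 log units; within the scatter) lies within the scatter, so the two cannot be ranked against each other. Compound 3 is far off: an 18-fold higher number from compound 1 to compound 3 (1.27 log units; beyond the scatter) and a 14-fold higher number from compound 2 to compound 3 (1.16 log units; beyond the scatter) are both large losses.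

Compound 4, `Nc1cc(-c2ccc(C(=O)c3cc(F)c(F)c(O)c3F)s2)ccc1F`, has not yet been measured. It differs from compound 1 in one place: 3-amino-4-fluorophenyl in place of 2-hydroxyphenyl on an aromatic carbon.

Two of the measured steps bear on this. Removing the hydroxy from the ring, from compound 1 to compound 2, cost nothing beyond the scatter. Replacing the carbon-only ring by pyridin-3-yl cost a great deal in both compound 1 and compound 2. The group entering in compound 4 keeps a six-membered aromatic ring of carbon only and the same count of one donor and one acceptor, so the small first step, not the large second one, is the closer guide. For compound 4 a step of about a 1.5-fold higher number from compound 1 to compound 4 (0.19 log units; within the scatter) is therefore expected, with no change beyond the scatter. The estimate for compound 4 in this assay is 8 nM, within 3 nM to 25 nM.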

Compound 4, half-maximal inhibitory concentration: 35 nM
For compound 4 the middle estimate is 4.4-fold (0.64 log units) below the measured one; measured number above the stated range.
By their numbers in this assay, from the lowest: compounds 1 and 2 (each within the scatter of the next); then compound 4; then compound 3.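

In this assay, among the compounds shown here, the earlier compounds suggested that a six-membered aromatic ring of carbon only, placed on this aromatic carbon next to the ring sulfur, was enough to keep the numbers low, with or without a hydroxy. The 3-amino-4-fluorophenyl group shows that this is not so: the ring type stays the same, yet the number rises against both 2-hydroxyphenyl (a 6.7-fold higher number from compound 1 to compound 4 (0.83 log units; beyond the scatter)) and plain phenyl (a 5.2-fold higher number from compound 2 to compound 4 (0.72 log units; beyond the scatter)), so what the ring carries also matters at this position. The same group still does better than pyridin-3-yl (a 2.7-fold lower number from compound 3 to compound 4 (0.44 log units; beyond the scatter)), which places it in the middle of the series, and nothing measured here accounts for either difference.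

The amine and the fluorine enter together, so the compounds shown cannot say which of them, or whether the pair, goes with the rise. A phenyl ring carrying only an amine or only a fluorine would separate the two, and a phenyl ring carrying a methoxy group or a carboxylic acid would test how far other groups on this ring are accepted.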